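The source may hold more compounds than are shown below. What is called first, only, known or untested is meant among the compounds shown, and "the series" means these compounds.

Compound 1 `C/C1=C\CC[C@@]2(C)O[C@@H]2[C@H]2OC(=O)[C@@H](Cn3cc(CO)nn3)[C@@H]2CC1`, compound 2 `C/C1=C\CC[C@@]2(C)O[C@@H]2[C@H]2OC(=O)[C@@H](Cn3cc(CCCCO)nn3)[C@@H]2CC1` and compound 3 `C/C1=C\CC[C@@]2(C)O[C@@H]2[C@H]2OC(=O)[C@@H](Cn3cc(-c4ccccc4)nn3)[C@@H]2CC1` share one core and differ only in the group attached to it. In a functional assay on HL-60 cells (Homo sapiens) for cytotoxicity, read by flow cytometry and annexin V staining, with a stated time of 18 h (a lower number here means a stronger inhibitor, a higher number a weaker inhibitor), compound 1 gives > 50000 nM, which is a limit of the assay and not a number. In this assay compound 2 likewise gives > 50000 nM, again a limit. Compound 3 gives > 50000 nM in this assay, also a limit. Compound 3 thus stands at the limit of > 50000 nM in this assay, at which 3 of the 3 values shown sit, and the steps a step that the two limits leave unreadable from compound 1 to compound 2, a step that the two limits leave unreadable from compound 1 to compound 3 and a step that the two limits leave unreadable from compound 2 to compound 3 all remain unreadable. Compound 4 `C/C1=C\CC[C@@]2(C)O[C@@H]2[C@H]2OC(=O)[C@@H](Cn3cc(-c4cccc(N)c4)nn3)[C@@H]2CC1` differs from compound 3 by amino in place of hydrogen on an aromatic carbon, phenyl to 3-aminophenyl. For the measured compounds named here, no measured step bears on this change, and nothing among the three values suggests the limit will be escaped. Compound 4 is expected to give about 60000 nM in this assay, between 15000 nM and 250000 nM, an estimated step that the limit leaves unreadable from compound 3 to compound 4.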

Compound 4, half-maximal inhibitory concentration: > 50000 nM
Compound 4: a limit, no number; the forecaster's own chance of this, stated with the estimate: 75%; the middle value lies beyond the limit too.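

In this assay, for the compounds shown here, compound 4 gives only a limit, not a number, so no step between it and compound 1, compound 2 or compound 3 can be read: the limit of > 50000 nM in this assay, at which 4 of the 4 values shown sit. The compounds shown leave open whether any group on the shared core gives a measurable value.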